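The source may report more compounds than this note shows. Statements on the series, on what has been measured and on what is new or still open speak of the compounds shown alone.

Compound 1 `CC1(C)CC(NC(=O)Nc2cccc(Cl)c2)c2cc(Br)ccc2O1` gives 69000 nM in a functional assay on U-373MG ATCC cells (Homo sapiens) for inhibition, read by MTT assay, with a stated time of 72 h; a lower number here means a stronger inhibitor, a higher number a weaker inhibitor. Compound 2 `CC1(C)CC(NC(=O)NCc2ccccc2)c2cc(Br)ccc2O1` gives 27000 nM in this assay, so the change benzyl in place of 3-chlorophenyl on an amide-type nitrogen brings a 2.6-fold lower number from compound 1 to compound 2 (0.41 log units; beyond the scatter). Compound 3 `CC1(C)CC(NC(=O)Nc2cccc(Cl)c2)c2cc(F)ccc2O1` carries fluoro in place of bromo on an aromatic carbon relative to compound 1. In this assay compound 3 gives 39000 nM, a move of a 1.8-fold lower number from compound 1 to compound 3 (0.25 log units; within the scatter).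

Compound 4 `CC1(C)CC(NC(=O)NCc2ccccc2)c2cc(F)ccc2O1` has not yet been measured. It differs from compound 3 by benzyl in place of 3-chlorophenyl on an amide-type nitrogen, the same change that turned compound 1 into compound 2, at a place described in the same words. The two cores differ by fluoro in place of bromo on an aromatic carbon. Since the step from compound 1 to compound 2 was a 2.6-fold lower number from compound 1 to compound 2 (0.41 log units; beyond the scatter) and the bromo-to-fluoro exchange gave only a 1.8-fold lower number from compound 1 to compound 3 (0.25 log units; within the scatter), the change from compound 3 to compound 4 is expected to lower the number by a similar modest amount, an estimated 2.4-fold lower number from compound 3 to compound 4 (0.39 log units; beyond the scatter) in this assay. Compound 4 is therefore estimated at 16000 nM in this assay, with a range from 6000 nM to 45000 nM.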

Compound 4, half-maximal inhibitory concentration: 11000 nM
Compound 4: middle estimate off by 1.5-fold (0.16 log units), on the high side; the measured number falls inside the stated range.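

In this assay, benzyl in place of 3-chlorophenyl on an amide-type nitrogen also lowers the number on the fluoro core, with a 3.5-fold lower number from compound 3 to compound 4 (0.55 log units; beyond the scatter), and this agrees with the step seen on the bromo core: the same change on two cores in this assay, a 2.6-fold lower number (0.41 log units; beyond the scatter) from compound 1 to compound 2 and a 3.5-fold lower number (0.55 log units; beyond the scatter) from compound 3 to compound 4, 1.4-fold (0.14 log units) apart, within the scatter of two such steps. Read the other way, fluoro in place of bromo on an aromatic carbon gives a 2.5-fold lower number from compound 2 to compound 4 (0.39 log units; beyond the scatter) with benzyl present, and this agrees with its reading with 3-chlorophenyl present: the same change on two cores in this assay, a 1.8-fold lower number (0.25 log units; within the scatter) from compound 1 to compound 3 and a 2.5-fold lower number (0.39 log units; beyond the scatter) from compound 2 to compound 4, 1.4-fold (0.14 log units) apart, within the scatter of two such steps. Across these four compounds, each change therefore carries from one core to the other with no detectable dependence on the other position, but this rests on a single square of compounds in one cell assay and does not show that it would hold for other groups or explain why the numbers fall.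

The compounds shown leave open whether the same carry-over would hold with a longer chain such as phenethyl on that nitrogen. They also leave open what a methoxy group or a nitrile in place of the halogen on that aromatic carbon would do.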